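Rat microsomal clearance: from compound 1 to compound 3

The compounds below may be only part of what the source reports. "The series", "measured", "known", "first", "only" and "open" are said of these compounds alone.

Measured in an ADME assay on microsomes from liver (Rattus norvegicus) for metabolic stability; a lower number here means slower removal, a higher number faster removal of the compound:
- compound 1 `CNc1nc(NC2(C#N)CCCCC2)nc(N(C)C)n1`: 276 mL/min/kg
- compound 2 `CCC(C)(C#N)Nc1nc(NC)nc(-n2cncn2)n1`: 32 mL/min/kg

Compound 1 holds the higher of the two numbers, and the gap to compound 2 lies beyond the scatter. Compound 3 `CNc1nc(NC2(C#N)CCCCC2)nc(-n2cnc(C#N)n2)n1` has 3-cyano-1H-1,2,4-triazol-1-yl in place of dimethylamino on an aromatic carbon. Within the data shown here, no measured pair differs in one place, so direct guidance is lacking. Compound 2 also carries a five-membered aromatic ring with 3 hetero atoms and gives 32 mL/min/kg. A lower number in this assay, beyond the scatter, is therefore expected, with an estimated step of a 3.1-fold lower number from compound 1 to compound 3 (0.49 log units; beyond the scatter). For compound 3 the estimate is 90 mL/min/kg, with an expected range of 35 mL/min/kg to 230 mL/min/kg.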

Compound 3, clearance: 210 mL/min/kg
Compound 3: the middle estimate sits 2.3-fold (0.37 log units) below what was measured, within the range that was stated.
By their numbers in this assay, from the lowest: compound 2; then compounds 3 and 1 (each within the scatter of the next).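

In this assay, 3-cyano-1H-1,2,4-triazol-1-yl in place of dimethylamino on an aromatic carbon gives a 1.3-fold lower number from compound 1 to compound 3 (0.12 log units; within the scatter) and so leaves the clearance within the scatter. At this position, opposite the ring nitrogen, the larger group with its five-membered aromatic ring and nitrile is thus accommodated with no measurable shift in this read-out. No measured evidence bears on this result. Whether the nitrile contributes remains open, as the core of compound 1 is not shown with an unsubstituted 1,2,4-triazol-1-yl. From the compounds shown here alone, how a morpholine would behave at this position also remains open.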